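From Cyclohexyl to Phenyl on the Nitrogen-Bound Carbon

A few compounds are considered here, and "the series" means these few. Any claim that something is new, unique, unknown or untested is made for them only; others in the source may bear on it.

Three compounds sharing one core were measured in an in vitro ADME assay on microsomes from liver (Homo sapiens) for metabolic stability; on this read-out lower numbers stand for a shorter-lived compound and higher numbers for a longer-lived compound. Compound 1 `CC(C)CCn1nc(-c2cccs2)c(O)c(C2=NS(=O)(=O)c3cc(OCC(N)=O)ccc3N2)c1=O` gives 0.383 h, and compound 2 `CCC(C)CCn1nc(-c2cccs2)c(O)c(C2=NS(=O)(=O)c3cc(OCC(N)=O)ccc3N2)c1=O` gives 0.417 h; the step of a 1.1-fold higher number from compound 1 to compound 2 (0.04 log units; within the scatter) stays within the scatter. Compound 3 `NC(=O)COc1ccc2c(c1)S(=O)(=O)N=C(c1c(O)c(-c3cccs3)nn(CC3CCCCC3)c1=O)N2` carries a cyclohexyl group on the saturated chain carbon bound to the aromatic nitrogen, and in this assay compound 3 reaches > 1 h, which is a limit of the assay rather than a number (the limit of > 1 h in this assay, at which 1 of the 3 values shown sits). Compound 3 therefore stands beyond the other two, since the steps of an at least 2.6-fold higher number from compound 1 to compound 3 (0.41 log units; beyond the scatter) and an at least 2.3-fold higher number from compound 2 to compound 3 (0.37 log units; beyond the scatter) both lie beyond the scatter.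

Compound 4 `NC(=O)COc1ccc2c(c1)S(=O)(=O)N=C(c1c(O)c(-c3cccs3)nn(Cc3ccccc3)c1=O)N2` differs from compound 3 by phenyl in place of cyclohexyl on a saturated chain carbon bound to an aromatic nitrogen. The measured steps all exchange one saturated group for another; none replaces cyclohexyl with an aromatic ring, so they frame the change only loosely. Because an at least 2.6-fold higher number from compound 1 to compound 3 (0.41 log units; beyond the scatter) and an at least 2.3-fold higher number from compound 2 to compound 3 (0.37 log units; beyond the scatter) were both at least modest gains on moving to the cyclohexyl, removing that group is expected to give back part of the gain, and the step of an at least 1.4-fold lower number from compound 3 to compound 4 (0.15 log units; that floor lies within the scatter) is estimated as a modest fall. Compound 4 is expected to give about 0.7 h, between 0.35 h and 1.4 h.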

Compound 4, half-life: 0.383 h
Beside the measured number, compound 4's estimate is 1.8-fold (0.26 log units) above it; low and high end bracket the measured number.
By their numbers in this assay, from the lowest: compounds 1, 4 and 2 (each within the scatter of the next). At a limit, above all of these: compound 3.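

In this assay, the step of an at least 2.6-fold lower number from compound 3 to compound 4 (0.41 log units; beyond the scatter) shows that at this position the saturated ring of compound 3 and the aromatic ring of compound 4 are not interchangeable, even though the heavy-atom count stays the same. Set against the open chains, the phenyl gives a 1.1-fold lower number from compound 2 to compound 4 (0.04 log units; within the scatter) and no change at the digits printed from compound 1 to compound 4 (within the scatter), so among these compounds a ring on this carbon does not by itself separate a compound from the isobutyl and 2-methylbutyl compounds. The value of compound 3, > 1 h, is a limit of the assay and not a number: the limit of > 1 h in this assay, at which 1 of the 4 values shown sits.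

Going by these compounds, how far the cyclohexyl compound truly lies from the others therefore remains open. Also open, on these data alone, is whether a cyclopentyl ring, a pyridyl ring or a cyclohexyl ring bearing a hydroxyl group on this carbon would read like compound 3 or like compound 4.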